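The source may hold more compounds than are shown below. What is called first, only, known or untested is meant among the compounds shown, and "the series" means these compounds.

Measured so far in a functional assay on ACHN cells (Homo sapiens) for cytotoxicity, read by sulforhodamine B assay, with a stated time of 72 h; on this read-out higher numbers stand for weaker inhibition of growth and lower numbers for stronger inhibition of growth:
compound 1 `O=C(Nc1cc(C(F)(F)F)cc(C(F)(F)F)c1)C1CCc2ccccc2N1C(=O)c1ccccc1Cl` gives 4700 nM.
compound 2 `O=C(Nc1ccccc1O)C1CCc2ccccc2N1C(=O)c1ccccc1Cl` gives 44200 nM.
compound 3 `CC(=O)N1c2ccccc2CCC1C(=O)Nc1cc(C(F)(F)F)cc(C(F)(F)F)c1` gives only a limit of the assay, > 70000 nM.

Compound 3 thus stands at the weak end of the series, resting on (the limit of > 70000 nM in this assay, at which 1 of the 3 values shown sits). Among the measured compounds shown here, the one measured step that reaches it, an at least 14-fold higher number from compound 1 to compound 3 (1.17 log units; beyond the scatter), shows how much is lost when the 2-chlorophenyl on the carbonyl carbon gives way to methyl. Compound 4 `CCCC(=O)N1c2ccccc2CCC1C(=O)Nc1cc(C(F)(F)F)cc(C(F)(F)F)c1` differs from compound 3 by ethyl in place of hydrogen on a saturated chain carbon bound to a carbonyl carbon. For the measured compounds named here, no measured pair reports a change of this kind, and it is a far smaller change than the measured step. Compound 4 is therefore expected to remain near the limit, with a step of a number no higher from compound 3 to compound 4 (the limit leaves the size open) not beyond the scatter. The estimate for compound 4 is 70000 nM, within 30000 nM to 160000 nM, and a limit rather than a number is quite possible again.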

Compound 4, concentration for 50% growth inhibition: 13900 nM
Beside the measured number, compound 4's estimate is 5.0-fold (0.70 log units) above it; measured number below the stated range.
By their numbers in this assay, from the lowest: compound 1; then compound 4; then compound 2. At a limit, above all of these: compound 3.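

On the saturated chain carbon bound to a carbonyl carbon, ethyl in place of hydrogen is not a silent change (an at least 5.0-fold lower number from compound 3 to compound 4 (0.70 log units; beyond the scatter)) and restores measurable growth inhibition without the 2-chlorophenyl. Propyl on the carbonyl carbon still falls short of 2-chlorophenyl (a 3.0-fold higher number from compound 1 to compound 4 (0.47 log units; beyond the scatter)) in the same read-out. The full size of the gain from ethyl stays undefined, since the value for compound 3 is a limit: the limit of > 70000 nM in this assay, at which 1 of the 4 values shown sits.

From the compounds shown here alone, whether a longer chain continues this gain or reverses it remains open. An amine or a carboxylic acid on this chain also remains untested within the compounds shown.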